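From methyl to propylcarbamoyl in a small amide series

A few compounds are considered here, and "the series" means these few. Any claim that something is new, unique, unknown or untested is made for them only; others in the source may bear on it.

Compound 1 `Cc1cccc(CN(C)C(=O)c2cc(Cl)c(O)cc2O)c1` gives 49300 nM
Compound 2 `Cc1ccc(CN(C)C(=O)c2cc(Cl)c(O)cc2O)cc1` gives 34300 nM
Compound 3 `Cc1ccccc1CN(C)C(=O)c1cc(Cl)c(O)cc1O` gives 47500 nM

In a functional assay on NCI-H1975 cells (Homo sapiens) for antiproliferative activity, with a stated time of 72 h (a higher number here means a weaker inhibitor of growth, a lower number a stronger inhibitor of growth), compound 2 gives 34300 nM and stands within the scatter of the other two compounds, with a 1.4-fold lower number from compound 1 to compound 2 (0.16 log units; within the scatter) and a 1.4-fold higher number from compound 2 to compound 3 (0.14 log units; within the scatter) as the steps. Compound 4 `CCCNC(=O)c1ccc(CN(C)C(=O)c2cc(Cl)c(O)cc2O)cc1` is not yet measured. The change is propylcarbamoyl in place of methyl on an aromatic carbon and amounts to propylcarbamoyl in place of methyl on an aromatic carbon, para to a large group. The third measured step is a 1.0-fold lower number from compound 1 to compound 3 (0.02 log units; within the scatter) and also lies within the scatter. All three steps only exchange 2-methylphenyl, 3-methylphenyl and 4-methylphenyl. None replaces the methyl group with a larger one, so the data give no direction for this change and the range must stay wide. No step beyond the scatter is expected. The estimated step is a 1.4-fold lower number from compound 2 to compound 4 (0.14 log units; within the scatter) and would stay within the scatter. In this assay the expected value for compound 4 is 25000 nM with 8000 nM to 60000 nM as the estimated range.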

Compound 4, concentration for 50% growth inhibition: 20800 nM
Compound 4: the middle estimate sits 1.2-fold (0.08 log units) above what was measured, and the stated range covers the measured number.
By their numbers in this assay, from the lowest: compounds 4, 2, 3 and 1 (each within the scatter of the next, the first and the last beyond it).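

At the aromatic carbon para to a large group, propylcarbamoyl in place of methyl gives a 1.6-fold lower number from compound 2 to compound 4 (0.22 log units; within the scatter) in this assay. The earlier compounds shown here only moved methyl around the ring, whereas this change shows that a much larger group, bringing a hydrogen-bond donor and a hydrogen-bond acceptor, can stand at this position without a step beyond the scatter. Nothing on hand says why the step stays this small.

Open, going by these compounds, is whether a carboxylic acid or a basic amine at this position would give a step beyond the scatter. Also open, on these data alone, is what a longer chain than propyl on the amide nitrogen, or a dimethylcarbamoyl group without the amide hydrogen, would do to the number.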